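Swapping a Small Thiourea Group for a Benzyl-Bearing One

This account rests on a few compounds, and the source may have more. Where it says the series, first, only, none or still open, it means among the compounds named here.

Measured so far:
compound 1, `Cc1cccc(NC2=C/C(=N/NC(N)=S)C(=O)N=C2Nc2cccc(C)c2)c1`, 2730 nM
compound 2, `Cc1ccc(NC2=C/C(=N/NC(N)=S)C(=O)N=C2Nc2ccc(C)cc2)cc1`, 4330 nM
compound 3, `Cc1cccc(NC2=C/C(=N/N=C(\N)SCc3ccccc3)C(=O)N=C2Nc2cccc(C)c2)c1`, 8720 nM

All three were tested in a functional assay on Bel-7402 cells (Homo sapiens) for antiproliferative activity, read by MTT assay, with a stated time of 72 h; a lower number here means a stronger inhibitor, a higher number a weaker inhibitor. Compound 1 and compound 2 share the same atoms joined differently; the difference between the two cores is not broken down here, and their values lie within the usual scatter of each other. From compound 1 to compound 3 one change is made, (a group of 11 heavy atoms (8 carbon, 2 nitrogen, 1 sulfur; one six-membered aromatic ring of carbon only) in place of a group of 4 heavy atoms (1 carbon, 2 nitrogen, 1 sulfur; no ring), on a double-bonded nitrogen), and it gave a 3.2-fold higher number from compound 1 to compound 3 (0.50 log units; beyond the scatter).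

Compound 4, `Cc1ccc(NC2=C/C(=N/N=C(\N)SCc3ccccc3)C(=O)N=C2Nc2ccc(C)cc2)cc1`, is not yet measured. It differs from compound 2 by a group of 11 heavy atoms (8 carbon, 2 nitrogen, 1 sulfur; one six-membered aromatic ring of carbon only) in place of a group of 4 heavy atoms (1 carbon, 2 nitrogen, 1 sulfur; no ring), on a double-bonded nitrogen, the same change, at the same place. Compound 4 is expected to show a 3.0-fold higher number from compound 2 to compound 4 (0.48 log units; beyond the scatter), because the same change gave a 3.2-fold higher number from compound 1 to compound 3 (0.50 log units; beyond the scatter) and because compound 2 starts from 4330 nM. The estimate for compound 4 in this assay is 13000 nM, with a likely range from 6000 nM to 28000 nM, resting on a single measured example of this change.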

Compound 4, half-maximal inhibitory concentration: 7680 nM
The estimate for compound 4 lay 1.7-fold (0.23 log units) above the measured number; low and high end bracket the measured number.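

In this assay, the same swap on the core of compound 2 gave a 1.8-fold higher number from compound 2 to compound 4 (0.25 log units; within the scatter). Set beside the earlier step, the two results do not differ measurably: the same change on two cores in this assay, a 3.2-fold higher number (0.50 log units; beyond the scatter) from compound 1 to compound 3 and a 1.8-fold higher number (0.25 log units; within the scatter) from compound 2 to compound 4, 1.8-fold (0.26 log units) apart, within the scatter of two such steps. This is consistent with the change carrying over between these two cores, but two pairs are a thin basis, and the second step alone cannot be told apart from repeat-measurement noise, so its true size on any further core remains unsettled.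

The compounds shown leave open what a smaller methyl group or a longer alkyl chain would do in place of the benzyl group. They also leave open whether an amine or a carboxylic acid on the benzyl ring would alter the result.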